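Swapping a Methoxyphenyl for a Bromophenyl on a Shared Core

The source may hold more compounds than are shown below. What is called first, only, known or untested is meant among the compounds shown, and "the series" means these compounds.

Two measured compounds share one core and differ only in the aryl group on a double-bonded chain carbon. Compound 1 `C=CCn1c(=O)/c(=C\c2cccc(Cl)c2)[nH]c(=O)/c1=C\c1ccccc1OC` carries a 3-chlorophenyl there, and in a functional assay on BGC-823 cells (Homo sapiens) for cytotoxicity, read by CCK-8 assay, with a stated time of 72 h (on this read-out higher numbers stand for weaker inhibition and lower numbers for stronger inhibition), compound 1 gives 4600 nM. For the measured compounds named here, compound 2 `C=CCn1c(=O)/c(=C\c2ccccc2OC)[nH]c(=O)/c1=C\c1ccccc1OC` carries a 2-methoxyphenyl instead, and in this assay compound 2 gives 13400 nM, the highest of the two numbers; the single measured step is a 2.9-fold higher number from compound 1 to compound 2 (0.46 log units; beyond the scatter). Compound 3 `C=CCn1c(=O)/c(=C\c2cccc(Br)c2)[nH]c(=O)/c1=C\c1ccccc1OC` is not yet measured. It differs from compound 2 in this way: 3-bromophenyl in place of 2-methoxyphenyl on a double-bonded chain carbon bound to an aromatic carbon. Going by the values given here, no measured step covers this exact swap, but the step of a 2.9-fold higher number from compound 1 to compound 2 (0.46 log units; beyond the scatter) describes a closely related exchange, moving from a 3-chlorophenyl to the same 2-methoxyphenyl, and a step of similar size in the opposite direction is therefore expected. Compound 3 is expected to show a 3.0-fold lower number from compound 2 to compound 3 (0.47 log units; beyond the scatter) in this assay. Compound 3 is estimated at 4500 nM, within a range from 1800 nM to 12000 nM.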

Compound 3, half-maximal inhibitory concentration: 5900 nM
The estimate for compound 3 lay 1.3-fold (0.12 log units) below the measured number; low and high end bracket the measured number.
By their numbers in this assay, from the lowest: compounds 1 and 3 (each within the scatter of the next); then compound 2.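

In this assay, 3-bromophenyl in place of 2-methoxyphenyl on a double-bonded chain carbon bound to an aromatic carbon gives a 2.3-fold lower number from compound 2 to compound 3 (0.36 log units; beyond the scatter), so a second halogen-bearing compound now stands apart from compound 2. Bromo in place of chloro on an aromatic carbon gives a 1.3-fold higher number from compound 1 to compound 3 (0.11 log units; within the scatter), which means that compound 1 and compound 3 cannot be told apart in this read-out, and this exchange of one halogen for the other shows no measurable effect here. Nothing available explains why either halogen-bearing compound differs from compound 2.

The compounds shown leave open whether a fluoro group, a nitrile or an amine on this aromatic ring would give a number close to those of compound 1 and compound 3. They also leave open how a plain phenyl ring would compare at this position.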